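The compounds below may be only part of what the source reports. "The series", "measured", "known", "first", "only" and "open" are said of these compounds alone.

Values in an ADME assay on CHO-K1 cells (Cricetulus griseus) for cytotoxicity, read by MTT assay, with a stated time of 24 h (a lower number here means that less compound is tolerated, a higher number that more compound is tolerated), by compound
compound 1 `S=C(Nc1ccc(Oc2ccccc2)cc1)Nc1ccc2[nH]ccc2c1` gives 36000 nM
compound 2 `CC(=O)c1ccc(NC(=S)Nc2ccc3[nH]ccc3c2)cc1` gives 154000 nM

Compound 2 holds the higher of the two numbers. Next is compound 3 `O=C(c1ccccc1)c1ccc(NC(=S)Nc2ccc3[nH]ccc3c2)cc1` with phenyl in place of methyl on a carbonyl carbon as the change, phenyl in place of methyl on a carbonyl carbon. Within the data shown here, only one measured step bears on it, namely a 4.3-fold higher number from compound 1 to compound 2 (0.63 log units; beyond the scatter) for acetyl in place of phenoxy on an aromatic carbon. Read in reverse, that modest step suggests a move down in this assay of similar or smaller size, probably beyond the scatter. The expected step is a 2.6-fold lower number from compound 2 to compound 3 (0.41 log units; beyond the scatter) and remains an estimate. For compound 3 the estimate is 60000 nM with an expected range from 25000 nM to 130000 nM as the working window.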

Compound 3, concentration lethal to 50% of the cells: 20000 nM
The estimate for compound 3 lay 3.0-fold (0.48 log units) above the measured number; the measured number lies below the stated range.
By their numbers in this assay, from the lowest: compounds 3 and 1 (each within the scatter of the next); then compound 2.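

In this assay, the carbonyl carbon is sensitive to what it carries: phenyl in place of methyl gives a 7.7-fold lower number from compound 2 to compound 3 (0.89 log units; beyond the scatter), so among these compounds the high number goes with acetyl and not with the carbonyl alone. Benzoyl in place of phenoxy gives a 1.8-fold lower number from compound 1 to compound 3 (0.26 log units; within the scatter), so these two groups cannot be told apart in this assay. Nothing measured here explains the change at the carbonyl carbon.

From the compounds shown here alone, whether the higher number needs methyl itself remains open. An ethyl chain or an amine on the carbonyl carbon would test this.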